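This account rests on a few compounds, and the source may have more. Where it says the series, first, only, none or still open, it means among the compounds named here.

In an ADME assay on DU-145 cells (Homo sapiens) for cytotoxicity, read by sulforhodamine B assay, with a stated time of 24 h (on this read-out higher numbers stand for lower toxicity in this test and lower numbers for higher toxicity in this test), compound 2 `O=C(/C=C/c1cc2ccccc2[nH]c1=O)c1ccc(O)cc1` stands at 38000 nM, and compound 1 `COc1ccc(C(=O)/C=C/c2cc3ccccc3[nH]c2=O)cc1` at 35800 nM lies within the scatter of it, so the two measured numbers do not separate. Compound 3 `O=C(/C=C/c1cc2ccccc2[nH]c1=O)c1ccc(Cl)cc1` differs from compound 2 by chloro in place of hydroxy on an aromatic carbon. For the measured compounds named here, the only measured step, a 1.1-fold higher number from compound 1 to compound 2 (0.03 log units; within the scatter), touched the same group on the same ring, exchanging methyl for hydrogen on the oxygen, and changed nothing beyond the scatter; it bears on the present change only loosely, as here the whole hydroxy leaves and chloro enters. Going by the values given here, no measured step covers an exchange of this kind. Among the compounds with values here, with a single small step as the only guide, the expected step of a 1.3-fold lower number from compound 2 to compound 3 (0.10 log units; within the scatter) in this assay is taken as none beyond the scatter, with a wide range to allow for the untested change. Compound 3 is therefore expected to give about 30000 nM, somewhere between 8000 nM and 100000 nM.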

Compound 3, concentration lethal to 50% of the cells: > 100000 nM
Compound 3 ended at the assay's limit (the forecaster's own chance of this, stated with the estimate: 15%); middle value at least 3.3-fold (0.52 log units) away from the limit.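

The earlier step from compound 1 to compound 2 changed only what sits on the oxygen, and it moved nothing beyond the scatter, so this aromatic carbon could have seemed insensitive to change. Replacing the oxygen-linked group itself tells a different story: in this assay the change gives an at least 2.6-fold higher number from compound 2 to compound 3 (0.42 log units; beyond the scatter), and from the methoxy compound it gives an at least 2.7-fold higher number from compound 1 to compound 3 (0.44 log units; beyond the scatter), both toward lower toxicity in this test. Compound 3 gives > 100000 nM, which is a limit of the assay and not a number: the limit of > 100000 nM in this assay, at which 1 of the 3 values shown sits.

The compounds shown leave open whether the loss of the oxygen or the arrival of chloro matters more. They also leave open how an amine or a carboxylic acid on this same carbon would read in this assay.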